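This account rests on a few compounds, and the source may have more. Where it says the series, first, only, none or still open, it means among the compounds named here.

Measured compounds:
compound 1, `O=C1CC(=C(c2ccccc2)c2ccccc2)C(=O)N1CCN1CCN(c2ccccc2)CC1`: 214 nM in an assay on membranes from Cerebral cortex for binding affinity to Adrenergic receptor alpha-1 (Rattus norvegicus), read by radioligand binding; a higher number here means a weaker inhibitor, a lower number a stronger inhibitor
compound 2, `COc1ccccc1N1CCN(CCN2C(=O)CC(=C(c3ccccc3)c3ccccc3)C2=O)CC1`: 71.5 nM
compound 3, `O=C1CC(=C(c2ccccc2)c2ccccc2)C(=O)N1CCCN1CCN(c2ccccc2)CC1`: 5.7 nM

Compound 3 gives the lowest number of the three in this assay. Its nearest neighbour is compound 2 at 71.5 nM, and compound 1 at 214 nM lies furthest away. Within the data shown here, no single-point step connects compound 3 to either of them; the values alone show that compound 3 sits well below both, by gaps that are beyond the scatter.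

Compound 4, `O=C1CC(=C(c2ccccc2)c2ccccc2)C(=O)N1CCCN1CCN(c2cccc(C(F)(F)F)c2)CC1`, differs from compound 3 by trifluoromethyl in place of hydrogen on an aromatic carbon. Among the measured compounds shown here, only one measured step concerns a substituent on this ring: a 3.0-fold lower number from compound 1 to compound 2 (0.48 log units; beyond the scatter). That step involves a different group at a different place and so bears only loosely on the present change, but it shows that a substituent on this ring can move the number by a modest amount, and there it moved it downward.

Compound 4 is therefore expected to give a number close to that of compound 3, shifted at most modestly downward, which is the estimated step of a 1.3-fold lower number from compound 3 to compound 4 (0.10 log units; within the scatter). The estimate for compound 4 is 4.5 nM, with a range from 1.5 nM to 14 nM.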

Compound 4, inhibition constant: 62.7 nM
Compound 4: middle estimate off by 14-fold (1.14 log units), on the low side, and the stated range ends below it.
By their numbers in this assay, from the lowest: compound 3; then compounds 4 and 2 (each within the scatter of the next); then compound 1.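

In this assay, placing trifluoromethyl on the phenyl ring gives an 11-fold higher number from compound 3 to compound 4 (1.04 log units; beyond the scatter), which shows that a substituent on this ring can raise the number as well as lower it, and by a large step. Among these compounds, the only earlier step on such a ring, a 3.0-fold lower number from compound 1 to compound 2 (0.48 log units; beyond the scatter), ran in the opposite direction, but it involved methoxy on a different chain, so its direction did not carry over to trifluoromethyl meta to a large group on the chain of compound 3. Nothing available here explains why the number rises with this change.

From the compounds shown here alone, it remains open whether the rise belongs to trifluoromethyl itself or would follow any group at this place, for instance whether a chlorine or a nitrile on that same carbon would raise the number as far. Also unsettled is whether the two substituent effects depend on the chain, that is, whether methoxy would still lower the number on the chain of compound 3, and whether trifluoromethyl would still raise it on the chain of compound 1.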